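This account rests on a few compounds, and the source may have more. Where it says the series, first, only, none or still open, it means among the compounds named here.

Measured so far in a functional assay on ECV-304 cells (Homo sapiens), read by MTT assay, with stated times of 24 h and 12 h; on this read-out lower numbers stand for an effect already at smaller amounts and higher numbers for an effect only at larger amounts of compound:
Compound 1 `Cc1nc(C)c(CSc2nnc(-c3cccs3)n2N)nc1C`: 330000 nM
Compound 2 `Cc1nc(C)c(CSc2nc(C)c(CC(=O)O)s2)nc1C`: 150000 nM

Compound 1 holds the higher of the two numbers in this assay, and compound 2 lies lower by more than the usual scatter of repeat measurements. Among the measured compounds shown here, these two compounds differ in more than one place, so the data offer no measured step for a single change.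

The next compound, compound 3 `Cc1nc(C)c(CSc2nnc(-c3ccco3)n2N)nc1C`, carries furan-2-yl in place of thiophen-2-yl on an aromatic carbon. Each of the two groups is one five-membered aromatic ring with 1 hetero atom, and the rest of the structure stays as in compound 1. No step beyond the scatter is expected in this assay, and no direction is favoured. The expectation is anchored on compound 1 at 330000 nM. The estimated change is a 1.1-fold lower number from compound 1 to compound 3 (0.04 log units; within the scatter). For compound 3 the estimated value is 300000 nM, with an expected range from 130000 nM to 650000 nM.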

Compound 3, half-maximal effective concentration: 420000 nM
Compound 3: middle estimate off by 1.4-fold (0.15 log units), on the low side; the range from low to high includes it.
By their numbers in this assay, from the lowest: compound 2; then compounds 1 and 3 (each within the scatter of the next).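

At the aromatic carbon of the five-membered aromatic ring with 3 nitrogen, between two ring nitrogen atoms, furan-2-yl in place of thiophen-2-yl gives in this assay a step of a 1.3-fold higher number from compound 1 to compound 3 (0.10 log units; within the scatter). This is the only measured step at this position among the compounds shown, and it shows that exchanging the sulfur of one five-membered aromatic ring with 1 hetero atom for the oxygen of the other does not move the number beyond the scatter, with compound 3 at 420000 nM and the same count of heavy atoms, donors and acceptors on both sides. No measurement at hand accounts for this result or bears on it.

The two compounds leave open how far this carbon accepts anything other than these two closely matched rings, such as a phenyl ring, a pyridine ring or a simple methyl group, any of which would change the group far more than this exchange does. They also leave open whether the amino group on the neighbouring ring atom matters to the number, which a hydrogen or a methyl group in its place would test.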